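This account rests on a few compounds, and the source may have more. Where it says the series, first, only, none or still open, it means among the compounds named here.

In a functional assay on WIL2-NS cells (Homo sapiens) (on this read-out lower numbers stand for stronger inhibition and higher numbers for weaker inhibition), three compounds sharing a core have been measured. Compound 3 `O=C(O)c1nn([C@@H]2O[C@H](CO)[C@@H](O)[C@H]2O)cc1I`, which carries a carboxy group, gives only a limit, > 300000 nM. Compound 1 `NC(=O)c1nn([C@@H]2O[C@H](CO)[C@@H](O)[C@H]2O)cc1I`, the matching amide, also gives only a limit, > 300000 nM. Compound 2 `COC(=O)c1nn([C@@H]2O[C@H](CO)[C@@H](O)[C@H]2O)cc1I`, the methyl ester, gives a true number, 1600 nM.

Compound 4 `CCCCOC(=O)c1nn([C@@H]2O[C@H](CO)[C@@H](O)[C@H]2O)cc1I` differs from compound 3 by butyl in place of hydrogen on an oxygen next to a carbonyl group, which turns carboxy into butoxycarbonyl. Among the measured compounds shown here, two measured steps bear on this change. The nearest is an at least 180-fold higher number from compound 2 to compound 3 (2.27 log units; beyond the scatter), where the methyl on that same oxygen is lost, so the change to compound 4 runs the opposite way. The other is an at least 180-fold lower number from compound 1 to compound 2 (2.27 log units; beyond the scatter), which also leads to an ester. Both are large, so a large step towards a lower number is expected in this assay. The expected step is an at least 250-fold lower number from compound 3 to compound 4 (2.39 log units; beyond the scatter). Butyl is longer than the methyl of compound 2, and no measured step shows what that adds, so the range stays wide. Compound 4 is estimated at 1200 nM, with an expected range from 200 nM to 8000 nM.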

Compound 4, half-maximal inhibitory concentration: 23000 nM
Beside the measured number, compound 4's estimate is 19-fold (1.28 log units) below it, outside the stated range (above it).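

In this assay butoxycarbonyl also stands clear of carboxy and of the amide, with an at least 13-fold lower number from compound 3 to compound 4 (1.11 log units; beyond the scatter) and with an at least 13-fold lower number from compound 1 to compound 4 (1.11 log units; beyond the scatter) as the two steps, so the lower numbers seen with compound 2 are not confined to the methyl ester. The new information is that the group on this oxygen matters and not merely the presence of an ester, as the longer chain gives a 14-fold higher number from compound 2 to compound 4 (1.16 log units; beyond the scatter) and so gives up part of that gain. The steps from compound 1 and compound 3 start from limits and give only a smallest size: the limit of > 300000 nM in this assay, at which 2 of the 4 values shown sit.

From the compounds shown here alone, with only methyl and butyl on this oxygen, the course along the chain remains open, and an ethyl or propyl ester would fill that gap. Going by these compounds, whether a branched isopropyl ester or a benzyl ester follows the same course also remains open.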